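Swapping a saturated ring for an aromatic one: permeability

The source may hold more compounds than are shown below. What is called first, only, known or untested is meant among the compounds shown, and "the series" means these compounds.

Measured compounds:
compound 1 `C[C@H]1Cn2c(nnc2C(F)(F)F)CN1C(=O)c1cccc(C(F)(F)c2n[nH]c(=O)c3c2CCCC3)c1`: 3.6 10^-6 cm/s
compound 2 `C[C@H]1Cn2c(nnc2C(F)(F)F)CN1C(=O)c1cccc(C(F)(F)c2n[nH]c(=O)c3ccccc23)c1`: 6.7 10^-6 cm/s
compound 3 `C[C@@H]1Cn2c(nnc2C(F)(F)F)CN1C(=O)c1cccc(Cc2n[nH]c(=O)c3c2CCCC3)c1`: 0.3 10^-6 cm/s

In an ADME assay on Caco-2 cells (Homo sapiens) for permeability, read by LC-MS, with a stated time of 2 h, at pH 7.4, tested at 10 uM (on this read-out higher numbers stand for higher permeability and lower numbers for lower permeability), these three were measured. Compound 1 and compound 3 share no counted difference; how their two cores differ is not broken down here. Compound 4 `C[C@@H]1Cn2c(nnc2C(F)(F)F)CN1C(=O)c1cccc(Cc2n[nH]c(=O)c3ccccc23)c1` has not been measured. It differs from compound 3 by a group of 11 heavy atoms (8 carbon, 2 nitrogen, 1 oxygen; one six-membered aromatic ring of carbon only, one six-membered aromatic ring with 2 hetero atoms) in place of a group of 11 heavy atoms (8 carbon, 2 nitrogen, 1 oxygen; one six-membered non-aromatic ring of carbon only, one six-membered aromatic ring with 2 hetero atoms), on a saturated chain carbon bound to an aromatic carbon. Compound 2 differs from compound 1 by a group of 11 heavy atoms (8 carbon, 2 nitrogen, 1 oxygen; one six-membered aromatic ring of carbon only, one six-membered aromatic ring with 2 hetero atoms) in place of a group of 11 heavy atoms (8 carbon, 2 nitrogen, 1 oxygen; one six-membered non-aromatic ring of carbon only, one six-membered aromatic ring with 2 hetero atoms), on a saturated chain carbon bound to an aromatic carbon and two fluorine atoms; the place there is a saturated chain carbon bound to an aromatic carbon and two fluorine atoms, so this is the same kind of change, not the same one. That step gave a 1.9-fold higher number from compound 1 to compound 2 (0.27 log units; within the scatter). A similar step is expected from compound 3 to compound 4, namely a 1.8-fold higher number from compound 3 to compound 4 (0.26 log units; within the scatter), because compound 3 gives 0.3 10^-6 cm/s and the earlier change was small. Compound 4 is therefore estimated at 0.55 10^-6 cm/s, between 0.2 10^-6 cm/s and 1.5 10^-6 cm/s.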

Compound 4, apparent permeability: 1.5 10^-6 cm/s
For compound 4 the middle estimate is 2.7-fold (0.44 log units) below the measured one, within the range that was stated.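

In this assay, putting the aromatic carbon ring in place of the non-aromatic carbon ring gave a 5.0-fold higher number from compound 3 to compound 4 (0.70 log units; beyond the scatter). The size of this step did not carry over between the two cores: the same change on two cores in this assay, a 1.9-fold higher number (0.27 log units; within the scatter) from compound 1 to compound 2 and a 5.0-fold higher number (0.70 log units; beyond the scatter) from compound 3 to compound 4, 2.7-fold (0.43 log units) apart, beyond the scatter of two such steps On these two pairs, then, a step measured on one core is no safe guide to its size on the other, but two pairs cannot show why the steps differ or which feature of the cores sets their size.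

On these data alone, it remains open how the same change would behave with a single fluorine atom or a methyl group on the saturated chain carbon bound to an aromatic carbon. A third such pair would show whether the step follows what that carbon carries.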